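An Undefined Double Bond in Compound 4

The source may hold more compounds than are shown below. What is called first, only, known or untested is meant among the compounds shown, and "the series" means these compounds.

Compound 1 `C(=C1/CN2CCC1CC2)\c1ccc(C2OCCO2)cc1`: 239000 nM
Compound 2 `C(=C1\CN2CCC1CC2)\c1ccc(-c2ccccc2)cc1`: 13400 nM
Compound 3 `C(=C1\CN2CCC1CC2)\c1ccc(C2OCCO2)cc1`: 136000 nM

In an ADME assay on L6 cells (Rattus norvegicus) for cytotoxicity, read by resazurin assay, with a stated time of 72 h (on this read-out lower numbers stand for stronger inhibition and higher numbers for weaker inhibition), compound 3 stands level with compound 1 within the scatter and well apart from compound 2, with a 10-fold higher number from compound 2 to compound 3 (1.01 log units; beyond the scatter). Compound 4 `C(=C1CN2CCC1CC2)c1ccc(C2OCCO2)cc1` has not yet been measured. Its difference from compound 3 is this: the two compounds have the same atoms and bonds; at least one stereo element is drawn with a configuration in one of them and without one in the other: 1 of 3 stereo elements differ; a double bond is drawn Z in compound 3 and without a configuration in compound 4. The step that bears on this change is a 1.8-fold lower number from compound 1 to compound 3 (0.24 log units; within the scatter), which joins the E and Z drawings and stays within the scatter. The large step from phenyl to 1,3-dioxolan-2-yl does not touch the double bond. The expected step is a 1.3-fold higher number from compound 3 to compound 4 (0.10 log units; within the scatter), so none beyond the scatter is expected. Compound 4 is estimated at 170000 nM, with an expected range of 90000 nM to 320000 nM.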

Compound 4, half-maximal inhibitory concentration: 212000 nM
Beside the measured number, compound 4's estimate is 1.2-fold (0.10 log units) below it; the range from low to high includes it.
By their numbers in this assay, from the lowest: compound 2; then compounds 3, 4 and 1 (each within the scatter of the next).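

With compound 4, all three drawings of the double bond can be compared in this assay, and none stands apart: the steps are a 1.6-fold higher number from compound 3 to compound 4 (0.19 log units; within the scatter) and a 1.1-fold lower number from compound 1 to compound 4 (0.05 log units; within the scatter). The undefined drawing therefore separates no further from the E and Z drawings than those two do from each other. The only difference between these compounds lies in how the double bond is drawn: the fact that one of compounds 3 and 4 is drawn with a defined configuration and the other without, at the place where they differ

The drawing of compound 4 does not tell whether it is one isomer or a mixture. Also open, on these data alone, is whether an amine or a carboxylic acid in place of 1,3-dioxolan-2-yl on an aromatic carbon would stay near these values or come closer to compound 2.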